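A few compounds are considered here, and "the series" means these few. Any claim that something is new, unique, unknown or untested is made for them only; others in the source may bear on it.

Of the compounds shown here, three have been measured so far. In a physicochemical assay for solubility, read by HPLC, using the shake flask method, in phosphate buffer, with a stated time of 20 h, at pH 6.5 (on this read-out lower numbers stand for lower solubility and higher numbers for higher solubility), compound 1 `CN1CCN(CC2CCN(c3nccc4[nH]c(-c5ccc(F)c(F)c5)nc34)CC2)CC1` gives 195000 nM, compound 2 `CN1CCN(C2CCN(c3nccc4[nH]c(-c5ccc(F)c(C(F)(F)F)c5)nc34)CC2)CC1` gives 195000 nM, and compound 3 `CN1CCN(CC2CCN(c3nccc4[nH]c(-c5ccc(F)c(Cl)c5)nc34)CC2)CC1` gives 155000 nM. The three numbers lie within the scatter of one another, so compound 3 stands level with the other two in this assay.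

Compound 4 `CN1CCN(CC2CCN(c3nccc4[nH]c(-c5ccc(F)c(C(F)(F)F)c5)nc34)CC2)CC1` follows from compound 3 with one change: trifluoromethyl in place of chloro on an aromatic carbon, ortho to a fluoro group and meta to a large group (trifluoromethyl in place of chloro on an aromatic carbon). The change turns 3-chloro-4-fluorophenyl into 4-fluoro-3-(trifluoromethyl)phenyl.

Within the data shown here, one measured step bears directly on this change, a swap of one substituent for another on an aromatic carbon. That step, a 1.3-fold lower number from compound 1 to compound 3 (0.10 log units; within the scatter), is small and stays within the scatter. There is also indirect evidence from compound 2, which carries the same 4-fluoro-3-(trifluoromethyl)phenyl group but differs elsewhere and still gives 195000 nM. Among the measured compounds shown here, no measured step shows the exact swap of chloro for trifluoromethyl, so the expectation rests on these two observations alone.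

No change beyond the scatter is therefore expected, and the expected step is a 1.0-fold lower number from compound 3 to compound 4 (0.01 log units; within the scatter). For compound 4 the estimated value is 150000 nM, with an expected range from 75000 nM to 260000 nM.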

Compound 4, solubility: 165000 nM
Beside the measured number, compound 4's estimate is 1.1-fold (0.04 log units) below it; the range from low to high includes it.
By their numbers in this assay, from the lowest: compounds 3, 4, 1 and 2 (each within the scatter of the next).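

At this aromatic carbon, ortho to a fluoro group and meta to a large group, the direct swap of chloro for trifluoromethyl reads in this assay as a 1.1-fold higher number from compound 3 to compound 4 (0.03 log units; within the scatter) and so stays within the scatter, even though 4 heavy atoms enter where 1 leaves. Alongside this, trifluoromethyl in place of fluoro at the same carbon gives a 1.2-fold lower number from compound 1 to compound 4 (0.07 log units; within the scatter) and so fluoro, chloro and trifluoromethyl now stand level with one another here, whereas the earlier compounds had directly compared only fluoro and chloro. Among these compounds, the result also gives the first matched comparison of the side chain, where (4-methylpiperazin-1-yl)methyl in place of 4-methylpiperazin-1-yl on a saturated ring carbon gives a 1.2-fold lower number from compound 2 to compound 4 (0.07 log units; within the scatter) and again stays within the scatter. Nothing measured here explains why these numbers stay level. The compounds shown leave open whether a group of another kind at this aromatic carbon, such as a carboxylic acid or a primary amine, would also leave the number level, since every substituent compared so far there is a halogen or trifluoromethyl.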